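Anilide variation on the shared core, MDA-MB-231 inhibition

The source may hold more compounds than are shown below. What is called first, only, known or untested is meant among the compounds shown, and "the series" means these compounds.

Measured so far:
compound 1 `O=C(CSc1nc(Nc2ccccc2)c2ccccc2n1)Nc1ccccc1Br`: 14100 nM
compound 2 `O=C(CSc1nc(Nc2ccccc2)c2ccccc2n1)Nc1cccc(Br)c1`: 17500 nM
compound 3 `O=C(CSc1nc(Nc2ccccc2)c2ccccc2n1)Nc1cccc([N+](=O)[O-])c1`: 33000 nM

In a functional assay on MDA-MB-231 cells (Homo sapiens) for inhibition, read by MTT assay, with a stated time of 72 h (on this read-out lower numbers stand for stronger inhibition and higher numbers for weaker inhibition), compound 1 holds the lowest of the recorded numbers; compound 2 stands nearest, a 1.2-fold higher number from compound 1 to compound 2 (0.09 log units; within the scatter), and compound 3 furthest, a 2.3-fold higher number from compound 1 to compound 3 (0.37 log units; beyond the scatter). Compound 4 `COc1cccc(NC(=O)CSc2nc(Nc3ccccc3)c3ccccc3n2)c1` differs from compound 1 by 3-methoxyphenyl in place of 2-bromophenyl on an amide-type nitrogen. Both recorded steps from compound 1 alter the same aryl group on the amide nitrogen: the step to compound 2 stays within the scatter, the step to compound 3 is a modest loss. Among the compounds with values here, no measured step covers a methoxy group, so these two steps carry the weight. A step of a 1.3-fold higher number from compound 1 to compound 4 (0.11 log units; within the scatter) is therefore expected, near compound 1 or slightly higher. Compound 4 is estimated at 18000 nM (range 8000 nM to 40000 nM).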

Compound 4, half-maximal inhibitory concentration: 21700 nM
For compound 4 the middle estimate is 1.2-fold (0.08 log units) below the measured one, and the stated range covers the measured number.
By their numbers in this assay, from the lowest: compounds 1, 2, 4 and 3 (each within the scatter of the next, the first and the last beyond it).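

Replacing bromo with methoxy on the aryl group gives a 1.2-fold higher number from compound 2 to compound 4 (0.09 log units; within the scatter) and replacing nitro with methoxy gives a 1.5-fold lower number from compound 3 to compound 4 (0.18 log units; within the scatter), so 3-methoxyphenyl is not resolved from either of the other substituted phenyl groups carrying a group at that printed ring number. The change from 2-bromophenyl to 3-methoxyphenyl, a 1.5-fold higher number from compound 1 to compound 4 (0.19 log units; within the scatter), is also not resolved, which leaves the step from compound 1 to compound 3 as the only one beyond the scatter. Nothing measured explains these close values.

As far as these compounds go, it remains open whether an amine or a carboxylic acid on this aryl group would stay in the same range. A longer chain on the amide nitrogen in place of the aryl group is equally untested by the compounds shown.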